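Swapping an octyl chain for a chlorophenyl ring

A few compounds are considered here, and "the series" means these few. Any claim that something is new, unique, unknown or untested is made for them only; others in the source may bear on it.

Measured compounds:
compound 1, `CCCCCCCCNc1nc(SCc2ccc(C(F)(F)F)cc2)nc2ccccc12`, 26100 nM in a functional assay on MCF7 cells (Homo sapiens) for cytotoxicity, read by MTT assay, with a stated time of 72 h; a higher number here means a weaker inhibitor, a lower number a stronger inhibitor
compound 2, `CCCCCCCCCCCCCCNc1nc(SCc2ccc(C(F)(F)F)cc2)nc2ccccc12`, > 50000 nM in this assay

Within the data shown here, compound 1 gives the only number among the two values shown, and in this assay compound 1 gives 26100 nM. Compound 2 reaches only a limit of the assay, > 50000 nM, and no number. The step from compound 1 to compound 2 is an at least 1.9-fold higher number from compound 1 to compound 2 (0.28 log units; that floor lies within the scatter), which puts hexyl in place of hydrogen on a saturated chain carbon, eight bonds along the chain from a nitrogen on an aromatic ring; the limit of > 50000 nM in this assay, at which 1 of the 2 values shown sits, means its true size is not known.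

Compound 3 is `FC(F)(F)c1ccc(CSc2nc(Nc3ccccc3Cl)c3ccccc3n2)cc1`. It differs from compound 1 by 2-chlorophenyl in place of octyl on a nitrogen on an aromatic ring, so that octylamino becomes (2-chlorophenyl)amino. No measured step makes this kind of exchange: the one step shown lengthens the chain rather than replacing it with a ring, and it ends at a limit. Little guidance therefore exists, and compound 3 is expected to sit close to compound 1, with the step from compound 1 to compound 3 estimated as a 1.3-fold lower number from compound 1 to compound 3 (0.12 log units; within the scatter). The estimate for compound 3 in this assay is 20000 nM, within a range from 5000 nM to 50000 nM.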

Compound 3, half-maximal inhibitory concentration: > 50000 nM
Compound 3: a limit, no number; the forecaster's own chance of this, stated with the estimate: 30%; middle value at least 2.5-fold (0.39 log units) away from the limit.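

On the nitrogen on an aromatic ring, the exchange of octyl for 2-chlorophenyl gives an at least 1.9-fold higher number from compound 1 to compound 3 (0.28 log units; that floor lies within the scatter), so this position has now been changed in two different ways, by lengthening the chain and by replacing it with a ring. Compound 3 gives > 50000 nM in this assay, which is a limit and not a number. Compound 1 therefore remains the only compound here with a number, and neither change on this nitrogen can be sized beyond a floor that lies within the scatter: the limit of > 50000 nM in this assay, at which 2 of the 3 values shown sit.

Going by these compounds, how far compound 3 truly lies from compound 1 stays open, as does whether its limit goes with the aromatic ring itself or with the chlorine on it. Plain phenyl on the same nitrogen would separate those two parts of the change, while a shorter chain such as butyl would show whether any group at this position gives a lower number than the octyl of compound 1.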